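Removing the primary alcohol: compound 2 to compound 3

A few compounds are considered here, and "the series" means these few. Any claim that something is new, unique, unknown or untested is made for them only; others in the source may bear on it.

Measured so far:
- compound 1 `C=C1C(=O)[C@H]2C[C@]1(O)CC1=C2[C@]2(C)CCC[C@](C)(CO)[C@H]2CC1`: "not determined" (no result reported) in a functional assay on NCI-H1299 cells (Homo sapiens) for cytotoxicity, read by MTT assay, with a stated time of 24 h; a higher number here means a weaker inhibitor, a lower number a stronger inhibitor
- compound 2 `C[C@@H]1C(=O)[C@H]2C[C@]1(O)CC1=C2[C@]2(C)CCC[C@](C)(CO)[C@H]2CC1`: > 50000 nM

Compound 1 carries an exocyclic methylene next to the ketone and gives "not determined" (no result reported) in this assay. Compound 2, with a methyl in place of that methylene, gives > 50000 nM in this assay, and this is a limit of the assay, not a number. Within the series compound 2 therefore stands only at the limit of > 50000 nM in this assay, at which 1 of the 2 values shown sits, with compound 1 giving no further reference point.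

Compound 3 `C[C@@H]1C(=O)[C@H]2C[C@]1(O)CC1=C2[C@]2(C)CCCC(C)(C)[C@H]2CC1` differs from compound 2 by hydrogen in place of hydroxy on a saturated chain carbon bound to a saturated ring carbon. Within the data shown here, no pair of measured compounds shows a step of this kind, so the size of the effect is open. Given that compound 2 already sits at a limit, the expected step from compound 2 to compound 3 is a step that the limit leaves unreadable from compound 2 to compound 3, with no evidence for movement beyond the scatter. Compound 3 is therefore estimated at 60000 nM in this assay, with a range from 20000 nM to 200000 nM, and it is expected that the assay again reports only a limit.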

Compound 3, half-maximal inhibitory concentration: > 50000 nM
Compound 3: only a limit was reported; the forecaster's own chance of this, stated with the estimate: 70%; the middle value is on the limit's open side.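

In this assay compound 3 gives > 50000 nM, which is a limit of the assay and not a number. Compound 2 also sits at a limit, and no step can be read between compound 2 and compound 3. The compounds shown leave open how large any effect of hydrogen in place of hydroxy is in this assay, since none of them gives a single number.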